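This account rests on a few compounds, and the source may have more. Where it says the series, first, only, none or still open, it means among the compounds named here.

Measured so far in an assay on CHO cells for displacement of a labelled ligand from melanin-concentrating hormone receptor 1 (Homo sapiens), read by scintillation counting, with a stated time of 1 h; on this read-out higher numbers stand for weaker inhibition and lower numbers for stronger inhibition:
compound 1, `Cc1c(C2CC2)nc2cnc(-n3ccc(OCc4ccc(Cl)cc4)cc3=O)cn12`, gives 44 nM.
compound 2, `Cn1c(CC(C)(C)C)nc2ccc(-n3ccc(OCc4ccc(F)cc4)cc3=O)cc21`, gives > 1000 nM; this is a limit of the assay, not a number.
compound 3, `Cn1c(C2CC2)nc2ccc(-n3ccc(OCc4cccc(Cl)c4)cc3=O)cc21`, gives 100 nM.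

Of the two numbers available in this assay, compound 3 holds the higher one; compound 1 sits lower by a gap that exceeds the usual scatter. Compound 2 stands at the limit of > 1000 nM in this assay, at which 1 of the 3 values shown sits.

Compound 4, `Cn1c(C2CC2)nc2ccc(-n3ccc(OCc4csc(Cl)c4)cc3=O)cc21`, is not yet measured. It differs from compound 3 by 5-chlorothiophen-3-yl in place of 3-chlorophenyl on a saturated chain carbon bound to an oxygen on an aromatic ring. Going by the values given here, no pair of measured compounds bears on a change of this kind, so only a small shift, if any, is expected, in either direction. Compound 4 is therefore expected at 150 nM, within 50 nM to 500 nM, which means an expected step of a 1.5-fold higher number from compound 3 to compound 4 (0.18 log units; within the scatter), near the scatter.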

Compound 4, half-maximal inhibitory concentration: 14 nM
Compound 4: middle estimate off by 11-fold (1.03 log units), on the high side; measured number below the stated range.
By their numbers in this assay, from the lowest: compound 4; then compound 1; then compound 3. At a limit, above all of these: compound 2.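

In this assay, 5-chlorothiophen-3-yl in place of 3-chlorophenyl on a saturated chain carbon bound to an oxygen on an aromatic ring gives a 7.1-fold lower number from compound 3 to compound 4 (0.85 log units; beyond the scatter). This position therefore responds to exchanging one chlorine-bearing aromatic ring for another while the rest of the molecule stays unchanged. No measured property at hand accounts for the step.

Going by these compounds, whether the chlorine of the 5-chlorothiophen-3-yl group is needed remains open. So does whether a 5-methylthiophen-3-yl or pyridinyl ring at this position would keep the lower number.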